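A fluorine added to compound 2

The source may hold more compounds than are shown below. What is called first, only, known or untested is meant among the compounds shown, and "the series" means these compounds.

Compound 1 `N/C(=N\NC(=S)N1CCCC1)c1ccc(F)cn1` and compound 2 `N/C(=N\NC(=S)N1CCSCC1)c1ccccn1` were tested in a functional assay on A-375 cells (Homo sapiens) for cytotoxicity, read by MTT assay, with a stated time of 72 h; on this read-out lower numbers stand for stronger inhibition and higher numbers for weaker inhibition. In this assay compound 1 gives 860 nM, and compound 2 gives 760 nM; the two numbers lie within the usual scatter of each other, so neither can be called stronger. Compound 3 `N/C(=N\NC(=S)N1CCSCC1)c1ccc(F)cn1` is compound 2 with one change: fluoro in place of hydrogen on an aromatic carbon. For the measured compounds named here, no measured pair shows what this change alone does, so the expected step of a 1.0-fold lower number from compound 2 to compound 3 (0.01 log units; within the scatter) is taken as nothing beyond the scatter, in either direction. Compound 3 is therefore expected to give 750 nM, with a range from 350 nM to 1600 nM.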

Compound 3, half-maximal inhibitory concentration: 900 nM
For compound 3 the middle estimate is 1.2-fold (0.08 log units) below the measured one; the range from low to high includes it.
By their numbers in this assay, from the lowest: compounds 2, 1 and 3 (each within the scatter of the next).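

In this assay fluoro in place of hydrogen, on the aromatic carbon para to a large group, gives a 1.2-fold higher number from compound 2 to compound 3 (0.07 log units; within the scatter) and so has no effect here that can be told from the scatter. With fluoro present on the ring, thiomorpholin-4-yl in place of pyrrolidin-1-yl on the thiocarbonyl carbon gives a 1.0-fold higher number from compound 1 to compound 3 (0.02 log units; within the scatter) and also stays within the scatter. Nothing measured here offers an explanation for either result. Going by these compounds, whether a methoxy group or an amine at this ring carbon would shift the number remains open.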